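Pyrazoline series: sulfonyl retained, piperazine replaced by triazole

A few compounds are considered here, and "the series" means these few. Any claim that something is new, unique, unknown or untested is made for them only; others in the source may bear on it.

Measured compounds:
compound 1, `Cc1ccc(C(=O)N2N=C(c3ccc(N4CCN(C)CC4)cc3)CC2c2ccc(N(C)C)cc2)cc1`, -0.4% in a functional assay on NCI-H1975 cells (Homo sapiens) for inhibition, read by sulforhodamine B assay, tested at 10 uM; on this read-out lower numbers stand for less inhibition and higher numbers for more inhibition at the one concentration tested (going by the name of the read-out)
compound 2, `CN1CCN(c2ccc(C3=NN(S(=O)(=O)c4ccc(F)cc4)C(c4ccc(N(C)C)cc4)C3)cc2)CC1`, 95.7%

Within the data shown here, compound 2 stands at the top of the two numbers so far; the only neighbour is compound 1, and the step of a number 96.1 percentage points higher from compound 1 to compound 2 (beyond the scatter) separates them. That step changed the group on the ring nitrogen and nothing else.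

Compound 3, `CN(C)c1ccc(C2CC(c3ccc(-n4cncn4)cc3)=NN2S(=O)(=O)c2ccc(F)cc2)cc1`, keeps the (4-fluorophenyl)sulfonyl of compound 2 and changes a different part of the molecule: 1H-1,2,4-triazol-1-yl in place of 4-methylpiperazin-1-yl on an aromatic carbon. Among the measured compounds shown here, no measured step touches this position; the one step in hand, a number 96.1 percentage points higher from compound 1 to compound 2 (beyond the scatter), concerns the ring-nitrogen substituent and says nothing about the group para to the pyrazoline carbon. The expectation therefore rests only on compound 2 holding the sulfonyl that carried it to 95.7%, with no guide to how far the new aromatic group may move the number.

The estimate for compound 3 is 70%, within 25% to 98%, meaning an expected step of a number 25.7 percentage points lower from compound 2 to compound 3 (beyond the scatter) relative to compound 2, with a wide range because nothing measured addresses this change.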

Compound 3, a percentage reported as inhibition, at one concentration (the size of the read-out at that concentration, not a potency): -0.5%
Estimate against measurement, compound 3: 70.5 percentage points above, outside the stated range (below it).
By their numbers in this assay, from the lowest: compounds 3 and 1 (each within the scatter of the next); then compound 2.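

Working notes on the group on the aromatic carbon, para to a large group: in this assay, the (4-fluorophenyl)sulfonyl does not carry the read-out by itself, as the swap of 4-methylpiperazin-1-yl for 1H-1,2,4-triazol-1-yl gives a number 96.2 percentage points lower from compound 2 to compound 3 (beyond the scatter). Together with a number 96.1 percentage points higher from compound 1 to compound 2 (beyond the scatter), this leaves compound 2, which holds both the sulfonyl and the 4-methylpiperazin-1-yl, as the only one of the three compounds with a high number, so each of the two places can decide the outcome in this small set. This single swap changes ring size, aromatic character and hetero atoms at once, so it cannot show which of these differences matters, and no measurement at hand explains the drop.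

On these data alone, it remains open whether the methyl of 4-methylpiperazin-1-yl is needed, which an unsubstituted piperazin-1-yl at the same carbon would test, and whether a morpholin-4-yl or piperidin-1-yl ring would keep the number high. A dimethylamino group there would address whether an open-chain amine can stand in for the six-membered ring.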